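Taking the bromo off compound 1

The source may report more compounds than this note shows. Statements on the series, on what has been measured and on what is new or still open speak of the compounds shown alone.

Three related compounds have been tested in a functional assay on 786-0 cells (Homo sapiens) for inhibition, read by spectrophotometry and sulforhodamine B assay, with a stated time of 48 h (a lower number here means a stronger inhibitor of growth, a higher number a weaker inhibitor of growth), so far. Compound 1 `Cc1ccc(N2C(=O)CS/C2=N/N=C/c2c[nH]c3ccc(Br)cc23)cc1` gives 39900 nM and stands second highest of the three numbers. Compound 2 `O=C1CS/C(=N/N=C/c2c[nH]c3ccccc23)N1c1cccc2ccccc12` gives 62100 nM and lies within the usual scatter of compound 1. Compound 3 `Cc1ccc(NC(=S)N/N=C/c2c[nH]c3ccccc23)cc1` gives 3990 nM and sits lower than compound 1 by a margin well beyond the scatter.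

Compound 4 `Cc1ccc(N2C(=O)CS/C2=N/N=C/c2c[nH]c3ccccc23)cc1` has not yet been measured. It is compound 1 with hydrogen in place of bromo on an aromatic carbon. For the measured compounds named here, no pair of tested compounds shows this single change alone, so the size of the step has to be judged indirectly. Compound 2 also has hydrogen at that place, and its value of 62100 nM stays close to the number for compound 1. Compound 3 has hydrogen there too but differs from compound 1 in other ways, so it says little about this one change.

The expectation is therefore no step beyond the scatter in this assay in either direction. The estimated step is a 1.1-fold higher number from compound 1 to compound 4 (0.05 log units; within the scatter) and would be too small to read as a real change. Compound 4 is expected to give about 45000 nM in this assay and an estimated range of 18000 nM to 100000 nM should hold the measurement.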

Compound 4, concentration for 50% growth inhibition: 79100 nM
Compound 4: middle estimate off by 1.8-fold (0.24 log units), on the low side, and the stated range covers the measured number.
By their numbers in this assay, from the lowest: compound 3; then compounds 1, 2 and 4 (each within the scatter of the next).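

For the compounds shown here, this is the first direct reading of this single change, and in this assay the step is a 2.0-fold higher number from compound 1 to compound 4 (0.30 log units; within the scatter) and so cannot be read as a real change. On the core of compound 1, therefore, bromo and hydrogen on this aromatic carbon of the six-membered ring cannot be told apart in growth inhibition, and the bromo brings no gain or loss that stands clear of the usual scatter. No measurement here explains why the exchange leaves the result within the scatter.

The compounds shown leave open whether a different group on the same aromatic carbon, such as a methoxy group, an amine or a carboxylic acid, would move the number beyond the scatter, or whether this position tolerates such changes as it does the loss of bromo. They also leave open whether bromo at this place would matter on the core of compound 3, which carries hydrogen there and has a different core from compound 1.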